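A few compounds are considered here, and "the series" means these few. Any claim that something is new, unique, unknown or untested is made for them only; others in the source may bear on it.

Measured compounds and their values:

Compound 1 `Cc1cccc(-n2nncc2CN2C(=O)C3(C(C#N)=C(N)Oc4c3c3nc5ccccc5nc3c3ccccc43)c3ccccc32)c1` gives in a functional assay on MCF7 cells (Homo sapiens) for antiproliferative activity, read by MTT assay, with a stated time of 48 h; on this read-out higher numbers stand for weaker inhibition and lower numbers for stronger inhibition > 50000 nM, which is a limit of the assay.
Compound 2 `N#CC1=C(N)Oc2c(c3nc4ccccc4nc3c3ccccc23)C12C(=O)N(Cc1cnnn1-c1ccc(Cl)cc1)c1ccccc12` gives in this assay > 50000 nM, again a limit.
Compound 3 `N#CC1=C(N)Oc2c(c3nc4ccccc4nc3c3ccccc23)C12C(=O)N(Cc1cnnn1-c1cccc(Br)c1)c1ccccc12` gives in this assay > 50000 nM, once more a limit.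

Compound 3 therefore stands where every measured compound of this set stands, at the limit of > 50000 nM in this assay, at which 3 of the 3 values shown sit. The step to compound 4 `COc1ccc(-n2nncc2CN2C(=O)C3(C(C#N)=C(N)Oc4c3c3nc5ccccc5nc3c3ccccc43)c3ccccc32)cc1` is 4-methoxyphenyl in place of 3-bromophenyl on an aromatic nitrogen. For the measured compounds named here, three measured steps bear on changes at this aromatic nitrogen or on its aryl group: a step that the two limits leave unreadable from compound 2 to compound 3, a step that the two limits leave unreadable from compound 1 to compound 2 and a step that the two limits leave unreadable from compound 1 to compound 3. None of them can be read, since both ends of each sit at the limit, so no size or direction of step in this assay can be derived from them. Compound 4 is accordingly expected to remain at the limit as well, with a step that the limit leaves unreadable from compound 3 to compound 4 that is expected to be no step beyond the scatter. The estimate for compound 4 is 60000 nM, with a range from 20000 nM to 200000 nM, most likely reported only as a limit.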

Compound 4, half-maximal inhibitory concentration: > 50000 nM
Compound 4 was reported as a limit (the forecaster's own chance of this, stated with the estimate: 85%); the middle value does not contradict the limit.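

For the compounds shown here, compound 4 gives > 50000 nM in this assay as a limit, so no step linking it to compound 1, compound 2 or compound 3 can be read: the limit of > 50000 nM in this assay, at which 4 of the 4 values shown sit. The compounds shown leave open whether any aryl group on this aromatic nitrogen gives a measurable value in this assay and how far such groups would differ.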